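A few compounds are considered here, and "the series" means these few. Any claim that something is new, unique, unknown or untested is made for them only; others in the source may bear on it.

Two compounds of the series carry cytotoxicity data. In an ADME assay on HEL cells (Homo sapiens) for cytotoxicity, with a stated time of 3 days (a higher number here means that more compound is tolerated, a lower number that less compound is tolerated), compound 1 `O=S1(=O)C=C(OCc2ccccc2)C(Cc2ccccc2)(Cc2ccccc2)O1` gives 200000 nM. Compound 2 `CCC1(Cc2ccccc2)OS(=O)(=O)C=C1OCc1ccc(C)cc1` reaches only a limit in this assay, >= 16000 nM, as noted in the limit of >= 16000 nM in this assay, at which 1 of the 2 values shown sits. Among the compounds with values here, no step between measured compounds is given, so the two values show only that compound 1 sits at a number and compound 2 at a limit. Compound 3 `CCC1(Cc2ccccc2)OS(=O)(=O)C=C1OCc1cccc(Cl)c1` differs from compound 2 by 3-chlorophenyl in place of 4-methylphenyl on a saturated chain carbon bound to an oxygen on an unsaturated carbon. Within the data shown here, with no measured step to lean on, the change is expected to leave the reading in this assay about where compound 2 stands, a step expected as a step that the limit leaves unreadable from compound 2 to compound 3. The minimum cytotoxic concentration of compound 3 is estimated at 50000 nM, with a range from 16000 nM to 200000 nM.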

Compound 3, minimum cytotoxic concentration: >= 20000 nM
Compound 3 was reported as a limit; the forecaster's own chance of this, stated with the estimate: 60%; the middle value lies beyond the limit too.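

Compound 2 and compound 3 both stand at limits rather than numbers, so no step can be read between them. The compounds shown leave open how 3-chlorophenyl and 4-methylphenyl compare in this assay.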